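Notes on a methoxy step across two cores

The source may report more compounds than this note shows. Statements on the series, on what has been measured and on what is new or still open speak of the compounds shown alone.

Measured so far in an ADME assay on HaCaT cells (Homo sapiens) for inhibition, read by sulforhodamine B assay, with a stated time of 48 h; on this read-out higher numbers stand for weaker inhibition of growth and lower numbers for stronger inhibition of growth:
compound 1, `O=c1ccoc(/C=C/c2ccccc2)c1`, gives 711 uM
compound 2, `COc1ccc(/C=C/c2cc(=O)cco2)cc1`, gives 710 uM
compound 3, `COc1ccc(/C=C/C2CC=CC(=O)N2)cc1`, gives only a limit of the assay, > 1090 uM

Compound 1 and compound 2 share one core and differ by methoxy in place of hydrogen on an aromatic carbon. The step from this change is a 1.0-fold lower number from compound 1 to compound 2 (0.00 log units; within the scatter), so the two values cannot be told apart in this assay. The value of compound 3 is a limit of the assay and not a number, and the limit of > 1090 uM in this assay, at which 1 of the 3 values shown sits, marks where it sits. The difference between the core of compound 1 and the core of compound 3 is not broken down here.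

Compound 4, `COc1ccc(/C=C/C2CC=CC(=O)N2)c(OC)c1`, is not yet measured. It differs from compound 3 by methoxy in place of hydrogen on an aromatic carbon. Among the compounds with values here, this is the same kind of change as the one from compound 1 to compound 2, but the surroundings are not the same: in compound 2 the entering methoxy stands para to a group of 9 heavy atoms, whereas in compound 4 it stands ortho to a group of 9 heavy atoms and meta to a methoxy group.

Within the data shown here, the only guide for the step from compound 3 to compound 4 in this assay is the step from compound 1 to compound 2, which lies within the scatter. On that basis a step that the limit leaves unreadable from compound 3 to compound 4 is expected, and the value of compound 4 is estimated to lie near 1500 uM, between 600 uM and 4000 uM, most likely again reported as a limit rather than a number.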

Compound 4, concentration for growth inhibition (reported as GI): > 964 uM
Compound 4: a limit, no number; the forecaster's own chance of this, stated with the estimate: 80%; the middle value does not contradict the limit.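

Compound 3 and compound 4 each give only a limit of the assay and not a number, so no step can be read between compound 3 and compound 4: the limit of > 964 uM in this assay, at which 1 of the 4 values shown sits.

The compounds shown leave open whether methoxy in place of hydrogen on an aromatic carbon changes the growth-inhibition value on the core of compound 3 at all, as no number exists on that core.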